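A Fluoro for Methoxy Change on an Inactive Amide Series

The compounds below may be only part of what the source reports. "The series", "measured", "known", "first", "only" and "open" are said of these compounds alone.

Three measured compounds share one core and differ only in the group on the amide nitrogen. Compound 1 `C=CC1=C(C(=O)NCc2ccc(Cl)cc2)C(c2ccc(OC)cc2)OC1` carries a 4-chlorobenzyl group there, compound 2 `C=CC1=C(C(=O)NC2CCCCC2)C(c2ccc(OC)cc2)OC1` a cyclohexyl, and compound 3 `C=CC1=C(C(=O)Nc2ccccc2OC)C(c2ccc(OC)cc2)OC1` a 2-methoxyphenyl. In a functional assay on QGY7701 cells (Homo sapiens) for cytotoxicity, read by MTT assay, with a stated time of 24 h (a higher number here means a weaker inhibitor, a lower number a stronger inhibitor), compound 1 gives only a limit, > 100000 nM. Compound 2 likewise gives only a limit in this assay, > 100000 nM. Compound 3 too reaches only a limit, > 100000 nM. All three values sit at the limit of > 100000 nM in this assay, at which 3 of the 3 values shown sit, so the steps among them cannot be read: a step that the two limits leave unreadable from compound 1 to compound 2, a step that the two limits leave unreadable from compound 1 to compound 3 and a step that the two limits leave unreadable from compound 2 to compound 3. Compound 2 therefore stands at the limit, with nothing in the numbers to set it apart from the other two.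

Compound 4 `C=CC1=C(C(=O)NC2CCCCC2)C(c2ccc(F)cc2)OC1` keeps the cyclohexyl amide of compound 2 and differs from it in one aromatic ring: fluoro in place of methoxy on an aromatic carbon. For the measured compounds named here, no measured step touches this ring, and none of the measured steps has a readable size, so the measured compounds give no direction to expect in this assay beyond the scatter. The three limits at the limit of > 100000 nM in this assay, at which 3 of the 3 values shown sit, lead to the expectation that compound 4 gives 150000 nM, within 40000 nM to 600000 nM, most likely again only as a limit. The expected step that the limit leaves unreadable from compound 2 to compound 4 is estimated to be none beyond the scatter.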

Compound 4, half-maximal inhibitory concentration: 40500 nM
Estimate against measurement, compound 4: 3.7-fold (0.57 log units) above, and the stated range covers the measured number.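

In this assay, for the compounds shown here, the change from 4-methoxyphenyl to 4-fluorophenyl gives an at least 2.4-fold lower number from compound 2 to compound 4 (0.39 log units; beyond the scatter), the only step in this set whose size can be read at all. The earlier steps shown here all changed the group on the amide nitrogen and could not be read, whereas this one changes the aromatic ring on the other side of the shared core and yields a real number rather than a limit, with compound 4 at 40500 nM. Going by these compounds, the step gives only a lower bound on the change and its full size stays unknown, as compound 2 has only a limit: the limit of > 100000 nM in this assay, at which 3 of the 4 values shown sit.

The compounds shown leave open whether the lower number comes from the fluoro itself or simply from losing the methoxy, a question that a plain hydrogen, a chloro or a trifluoromethyl at the same place on the ring could help to settle. They also leave open whether the same fluoro for methoxy change would bring a measurable number with the 4-chlorobenzyl amide of compound 1 or the 2-methoxyphenyl amide of compound 3.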